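Ethylamino in Place of Piperidinyl on the Cyclohexane Carbon

The source may hold more compounds than are shown below. What is called first, only, known or untested is meant among the compounds shown, and "the series" means these compounds.

Measured so far:
compound 1 `CN(C)C1CCC(COCc2cc(C(F)(F)F)cc(C(F)(F)F)c2)(c2ccccc2)CC1`: 48 nM
compound 2 `FC(F)(F)c1cc(COCC2(c3ccccc3)CCC(N3CCCCC3)CC2)cc(C(F)(F)F)c1`: 93 nM

Both compounds share the same core and differ only in the amine on the saturated ring carbon. In an assay on isolated protein for antagonist activity at Substance-P receptor (Homo sapiens) (a lower number here means a stronger inhibitor, a higher number a weaker inhibitor), compound 1 gives 48 nM and compound 2 gives 93 nM. Among the measured compounds shown here, the two values sit within the scatter of one another, as the single measured step shows: a 1.9-fold higher number from compound 1 to compound 2 (0.29 log units; within the scatter). Compound 2 therefore does not stand apart from compound 1 on the numbers at hand.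

Compound 3 `CCNC1CCC(COCc2cc(C(F)(F)F)cc(C(F)(F)F)c2)(c2ccccc2)CC1` keeps the core of compound 2 and changes only the amine: ethylamino in place of piperidin-1-yl on a saturated ring carbon. For the measured compounds named here, the one measured step that bears on this position is the exchange of dimethylamino for piperidin-1-yl, which moved the number by a 1.9-fold higher number from compound 1 to compound 2 (0.29 log units; within the scatter). Since that swap between two tertiary amines stayed within the scatter, the further move to a secondary ethylamino is expected to stay in the same region, with no step beyond the scatter in either direction: a 1.4-fold lower number from compound 2 to compound 3 (0.16 log units; within the scatter). Compound 3 is estimated at 65 nM, with a range from 20 nM to 200 nM.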

Compound 3, half-maximal inhibitory concentration: 14 nM
For compound 3 the middle estimate is 4.6-fold (0.67 log units) above the measured one; measured number below the stated range.
By their numbers in this assay, from the lowest: compound 3; then compounds 1 and 2 (each within the scatter of the next).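

In this assay, this position proves sensitive to the choice of amine: the exchange of dimethylamino for piperidin-1-yl had stayed within the scatter, whereas ethylamino gives a 6.6-fold lower number from compound 2 to compound 3 (0.82 log units; beyond the scatter) when it replaces piperidin-1-yl and a 3.4-fold lower number from compound 1 to compound 3 (0.54 log units; beyond the scatter) when it replaces dimethylamino. With both steps beyond the scatter, compound 3 is the strongest inhibitor of the three, while compounds 1 and 2 remain within the scatter of each other. Compared with piperidin-1-yl, ethylamino has no ring, fewer heavy atoms and a hydrogen-bond donor, and nothing available shows which of these differences accounts for the lower number.

The compounds shown leave open whether the gain follows the hydrogen on the nitrogen or the size and shape of the group, a question that diethylamino, with its two ethyl chains and no such hydrogen, would help to separate from the effect of the ethyl chain itself. They also leave open how far the trend runs among amines that keep that hydrogen, such as a primary amine, methylamino or the longer propylamino.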